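A few compounds are considered here, and "the series" means these few. Any claim that something is new, unique, unknown or untested is made for them only; others in the source may bear on it.

Working notes on the series. Compound 3 `N#Cc1c(-c2cc(Cl)c3c(ccn3CC3CC3)c2)ccn2c(CC(F)(F)F)cnc12` carries a cyano on the shared core; in a functional assay on CHO cells for agonist activity at metabotropic glutamate receptor 2 (Homo sapiens) (on this read-out higher numbers stand for larger maximal responses and lower numbers for smaller maximal responses), compound 3 gives 200%. Compound 1 `FC(F)(F)Cc1cnc2c(Cl)c(-c3cc(Cl)c4c(ccn4CC4CC4)c3)ccn12` differs from it by one change, (chloro in place of cyano on an aromatic carbon), and in this assay compound 1 gives 193%; the step of a number 7 percentage points lower from compound 3 to compound 1 (within the scatter). Compound 2 `N#Cc1c(-c2ccc3c(ccn3[C@H]3CC[C@H](O)CC3)c2)ccn2c(CC(F)(F)F)cnc12` has a different substituent pattern on the other ring system; the difference between the two cores is not broken down here. In this assay compound 2 gives 237%, the highest of the three numbers, with compound 3 and compound 1 both beyond the scatter below it.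

Compound 4 `O[C@H]1CC[C@H](n2ccc3cc(-c4ccn5c(CC(F)(F)F)cnc5c4Cl)ccc32)CC1` is not yet measured. It stands to compound 2 as compound 1 stands to compound 3: the change is chloro in place of cyano on an aromatic carbon, the same change, at the same place, as the one already measured. Since that earlier step left the maximal response essentially unchanged, the step from compound 2 to compound 4 is estimated as a number 12 percentage points lower from compound 2 to compound 4 (beyond the scatter), resting on the measured a number 7 percentage points lower from compound 3 to compound 1 (within the scatter). On that basis compound 4 is expected to give about 225% in this assay, with a plausible range from 190% to 260%.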

Compound 4, largest response reached (Emax), in percent of the reference or control that the assay uses: 244%
The estimate for compound 4 lay 19 percentage points below the measured number; low and high end bracket the measured number.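

In this assay, chloro in place of cyano on an aromatic carbon reads as a number 7 percentage points higher from compound 2 to compound 4 (within the scatter). Set beside the earlier step, the change behaves alike on the two cores: the same change on two cores in this assay, a number 7 percentage points lower (within the scatter) from compound 3 to compound 1 and a number 7 percentage points higher (within the scatter) from compound 2 to compound 4, 14 percentage points apart, within the scatter of two such steps

Within these two pairs, the change can therefore be carried from one core to the other with no detectable shift in maximal response. This does not show that chloro and cyano are interchangeable on other cores or on any other read-out, and two pairs cannot reveal a small effect hidden in the scatter.

The compounds shown carry only cyano or chloro at this aromatic carbon, so it remains open whether a methyl, a methoxy or a bromo group there would also leave the maximal response unchanged. From the compounds shown here alone, it also remains open whether the result would hold with an amine or a carboxylic acid in place of the hydroxy group of compound 2 and compound 4.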